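Methoxy in Place of Dimethylamino on a Shared Core

The source may report more compounds than this note shows. Statements on the series, on what has been measured and on what is new or still open speak of the compounds shown alone.

The measured compounds and their values in a functional assay on A549 cells (Homo sapiens), read by MTT assay, with a stated time of 72 h; a lower number here means a stronger inhibitor, a higher number a weaker inhibitor:
compound 1, `COc1ncnc2c1c(-c1cccs1)cn2[C@@H]1O[C@H](CO)[C@@H](O)[C@H]1O`, gives 4850 nM
compound 2, `CN(C)c1ncnc2c1c(-c1cccs1)cn2[C@@H]1O[C@H](CO)[C@@H](O)[C@H]1O`, gives only a limit of the assay, > 20000 nM
compound 3, `CN(C)c1ncnc2c1c(-c1cc3ccccc3o1)cn2[C@@H]1O[C@H](CO)[C@@H](O)[C@H]1O`, likewise gives only a limit of the assay, > 20000 nM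

Compound 2 and compound 1 share a core and differ in one place: methoxy in place of dimethylamino on an aromatic carbon. In this assay this change brought an at least 4.1-fold lower number from compound 2 to compound 1 (0.61 log units; beyond the scatter). Since compound 2 sits at the limit of > 20000 nM in this assay, at which 2 of the 3 values shown sit, only the lower bound of that step is known, and the true step may be larger.

Compound 2 and compound 3 differ in their cores: 1-benzofuran-2-yl in place of thiophen-2-yl on an aromatic carbon. Here a step that the two limits leave unreadable from compound 2 to compound 3, as both compound 2 and compound 3 sit at the limit of > 20000 nM in this assay, at which 2 of the 3 values shown sit.

Compound 4, `COc1ncnc2c1c(-c1cc3ccccc3o1)cn2[C@@H]1O[C@H](CO)[C@@H](O)[C@H]1O`, has not yet been measured in this assay. It differs from compound 3 by methoxy in place of dimethylamino on an aromatic carbon. The place of this change is described word for word as for the change from compound 2 to compound 1, so it is the same change, now made on the core of compound 3.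

Compound 4 is expected to show an at least 2.5-fold lower number from compound 3 to compound 4 (0.39 log units; beyond the scatter) in this assay, an expectation that rests on the step of an at least 4.1-fold lower number from compound 2 to compound 1 (0.61 log units; beyond the scatter) seen with compound 2 and compound 1. Because compound 3 sits at the limit of > 20000 nM in this assay, at which 2 of the 3 values shown sit, the starting point of the expected step is itself only a limit, so the estimate for compound 4 is expected to be 8000 nM, lying between 2000 nM and 20000 nM.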

Compound 4, half-maximal inhibitory concentration: 17700 nM
Compound 4: the middle estimate sits 2.2-fold (0.34 log units) below what was measured; measured number inside the range.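

In this assay, methoxy in place of dimethylamino on the core of compound 3 brought an at least 1.1-fold lower number from compound 3 to compound 4 (0.05 log units; that floor lies within the scatter), and on that core the thiophen-2-yl to 1-benzofuran-2-yl swap within the methoxy pair can now be read as a 3.6-fold higher number from compound 1 to compound 4 (0.56 log units; beyond the scatter). Set beside the earlier case, the change shows no reversal on the second core, but its floor there is too small to show a gain by itself, and nothing fixes how much of the step carries over: the same change on two cores in this assay, an at least 4.1-fold lower number (0.61 log units; beyond the scatter) from compound 2 to compound 1 and an at least 1.1-fold lower number (0.05 log units; that floor lies within the scatter) from compound 3 to compound 4; the limit leaves it open whether they differ The true size of both steps, and the thiophen-2-yl to 1-benzofuran-2-yl step between the two dimethylamino compounds, which cannot be read, stay unknown because compound 2 and compound 3 both stand at a limit of the assay: the limit of > 20000 nM in this assay, at which 2 of the 4 values shown sit.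

With only two cores, each carrying the same pair of groups, the compounds shown cannot say whether the methoxy step would recur with another aromatic group in place of thiophen-2-yl or 1-benzofuran-2-yl. They also leave open how a longer chain such as ethoxy, or a primary amine, would read on the same aromatic carbon.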